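Trimming a Side Chain: From Isobutyl to Propyl

The compounds below may be only part of what the source reports. "The series", "measured", "known", "first", "only" and "open" are said of these compounds alone.

Of the compounds shown here, two built on a shared core have so far been measured in a physicochemical assay for solubility, read by spectrophotometry, using the shake flask method, in phosphate buffer, measured as thermodynamic solubility, with a stated time of 72 h, at pH 7.4; a lower number here means a less soluble compound, a higher number a more soluble compound. Compound 1, `C=C1CN(S(=O)(=O)c2ccc(C)cc2)CCc2cc(O)cc(n2)CCN(S(=O)(=O)c2ccc(C)cc2)C1`, bears a hydroxy group on the aromatic ring, and in this assay compound 1 gives 27000 nM. Compound 2, `C=C1CN(S(=O)(=O)c2ccc(C)cc2)CCc2cc(CC(C)C)cc(n2)CCN(S(=O)(=O)c2ccc(C)cc2)C1`, carries an isobutyl group in place of that hydroxy, and in this assay compound 2 gives 29000 nM. Among the compounds with values here, the single step between them, a 1.1-fold higher number from compound 1 to compound 2 (0.03 log units; within the scatter), shows that the exchange of hydroxy for isobutyl left the solubility essentially unchanged, so compound 2 stands alongside compound 1 with no separation beyond the scatter.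

Compound 3, `C=C1CN(S(=O)(=O)c2ccc(C)cc2)CCc2cc(CCC)cc(n2)CCN(S(=O)(=O)c2ccc(C)cc2)C1`, has not yet been measured. It differs from compound 2 by one counted change: hydrogen in place of methyl on a saturated chain carbon bound to two saturated chain carbons. Within the data shown here, only the step from compound 1 to compound 2 bears on this, and it was within the scatter even though a whole isobutyl was installed; the loss of a methyl from that chain is a smaller change still. Compound 3 is therefore expected to show a step of a 1.1-fold higher number from compound 2 to compound 3 (0.04 log units; within the scatter), within the scatter. The solubility of compound 3 in this assay is estimated at 32000 nM, with a range from 15000 nM to 65000 nM.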

Compound 3, solubility: 18000 nM
The estimate for compound 3 lay 1.8-fold (0.25 log units) above the measured number; measured number inside the range.
By their numbers in this assay, from the lowest: compounds 3, 1 and 2 (each within the scatter of the next).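

Trimming the isobutyl of compound 2 to the propyl of compound 3 is the first change here made within the side chain rather than to the whole group, and in this assay it gives the step of a 1.6-fold lower number from compound 2 to compound 3 (0.21 log units; within the scatter) on replacing methyl with hydrogen on a saturated chain carbon bound to two saturated chain carbons. Propyl in place of hydroxy on the aromatic carbon gives the step of a 1.5-fold lower number from compound 1 to compound 3 (0.18 log units; within the scatter) and so also stays inside the usual variation of repeated measurements, which means that hydroxy, isobutyl and propyl at this place cannot be told apart in this assay on the three compounds shown. No accompanying measurement bears on what lies behind these numbers.

The compounds shown leave open whether any group on this aromatic carbon would produce a step beyond the scatter in this assay, since an amine, a carboxylic acid and a chain longer than isobutyl do not appear among them. They also leave open whether shortening the chain further, to ethyl or to methyl, would behave as this single trimming did.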